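Swapping the bromophenyl arm of compound 2 for a methylphenyl arm

This account rests on a few compounds, and the source may have more. Where it says the series, first, only, none or still open, it means among the compounds named here.

Measured compounds:
compound 1 `O=c1cc(CNCc2ccccc2[N+](=O)[O-])oc2ccc(O)c(O)c12` — 41300 nM
compound 2 `O=c1cc(CNCc2cccc(Br)c2)oc2ccc(O)c(O)c12` — > 100000 nM

The two measured compounds share one core and differ only in the aryl group hung on the saturated chain carbon bound to an amine nitrogen. In an ADME assay on Huh-7 cells (Homo sapiens) for cytotoxicity (on this read-out higher numbers stand for lower toxicity in this test and lower numbers for higher toxicity in this test), compound 1 gives 41300 nM. For compound 2 the assay reports only a limit, > 100000 nM, so compound 2 stands at the edge of what the assay can resolve rather than at a number, as the limit of > 100000 nM in this assay, at which 1 of the 2 values shown sits, records. Within the data shown here, because no two measured compounds differ in a single place, no step between them is given here, and nothing more is said of their pair than what the two values show.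

Compound 3 `Cc1ccc(CNCc2cc(=O)c3c(O)c(O)ccc3o2)cc1` is not yet measured. It differs from compound 2 by 4-methylphenyl in place of 3-bromophenyl on a saturated chain carbon bound to an amine nitrogen. Both arms carry no donors and no acceptors and no charge, and the place of the change is the same. In this assay the step from compound 2 to compound 3 is therefore expected to be none beyond the usual scatter, and the assay may again report only a limit. Compound 3 is thus estimated at 100000 nM, within 40000 nM to 250000 nM, with the expected step being a number no higher from compound 2 to compound 3 (the limit leaves the size open).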

Compound 3, half-maximal cytotoxic concentration: > 100000 nM
Compound 3 gave a limit, no number; the forecaster's own chance of this, stated with the estimate: 60%; the middle value lies on the limit itself.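

Among these compounds, compound 2 and compound 3 both stand at a limit of the assay rather than at a number, so no step between them can be read: the limit of > 100000 nM in this assay, at which 2 of the 3 values shown sit.

The compounds shown leave open how far either value in this assay lies beyond that limit, and so whether 4-methylphenyl and 3-bromophenyl differ at all in this read-out.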